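The compounds below may be only part of what the source reports. "The series", "measured", "known", "first", "only" and "open" are said of these compounds alone.

Measured so far in an ADME assay on the whole organism (Macaca fascicularis) for metabolic stability, read by LC-MS, using cassette dosing, at a dose of 1 mg/kg by the oral route; on this read-out lower numbers stand for a shorter-lived compound and higher numbers for a longer-lived compound:
compound 1 `CCCCN(c1nc2ccccc2o1)[C@H](C)c1ccc(-c2ccccc2-c2nnn[nH]2)cc1`, 3.2 h
compound 2 `CCCCN(c1nc2c(NS(C)(=O)=O)cccc2o1)[C@H](C)c1ccc(-c2ccccc2-c2nnn[nH]2)cc1`, 4.7 h
compound 3 `Cc1ccc(-c2nc(=O)o[nH]2)c(-c2ccc([C@@H](C)N(CC3CC3)c3nc4c(C(=O)O)cccc4o3)cc2)c1`, 2.8 h

Compound 2 cannot be told apart from compound 1 or from compound 3 on these numbers; all three lie within the scatter of one another. Among the compounds with values here, the one single-point step measured, a 1.5-fold higher number from compound 1 to compound 2 (0.17 log units; within the scatter), stays within the scatter.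

Compound 4 `CCCCN(c1nc2c(C(=O)NS(C)(=O)=O)cccc2o1)[C@H](C)c1ccc(-c2ccccc2-c2nnn[nH]2)cc1` differs from compound 2 by (methylsulfonyl)carbamoyl in place of methanesulfonamido on an aromatic carbon. Within the data shown here, no measured step covers this exchange; the step from compound 1 to compound 2, which added the group that now leaves, was within the scatter, and no compound shows the group that enters. Compound 4 is therefore expected to sit close to compound 2, with a 1.0-fold lower number from compound 2 to compound 4 (0.02 log units; within the scatter) not beyond the scatter. The estimate for compound 4 in this assay is 4.5 h, range 2.3 h to 9 h.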

Compound 4, half-life: 2.7 h
Compound 4: the middle estimate sits 1.7-fold (0.22 log units) above what was measured; the range from low to high includes it.
By their numbers in this assay, from the lowest: compounds 4, 3, 1 and 2 (each within the scatter of the next).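

In this assay the step of a 1.7-fold lower number from compound 2 to compound 4 (0.24 log units; within the scatter) and the step of a 1.2-fold lower number from compound 1 to compound 4 (0.07 log units; within the scatter) both stay within the scatter. On this aromatic carbon, hydrogen, methanesulfonamido and (methylsulfonyl)carbamoyl therefore cannot be told apart, even though the last two differ in heavy atoms and hydrogen-bond acceptors. Nothing available explains the half-lives of these compounds.

Going by these compounds, whether an amine or a methoxy group on this aromatic carbon would give a step beyond the scatter stays open. So does whether these exchanges would read the same with a longer chain in place of butyl.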